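The source may hold more compounds than are shown below. What is called first, only, known or untested is meant among the compounds shown, and "the series" means these compounds.

Measured compounds:
compound 1 `N#CC1=C(N)Oc2c(N)cc3nc4ccccc4nc3c2C12C(=O)N(Cc1cnnn1-c1cccc(Br)c1)c1ccccc12`: in a functional assay on HCT-116 cells (Homo sapiens) for antiproliferative activity, read by MTT assay, with a stated time of 48 h (a lower number here means a stronger inhibitor, a higher number a weaker inhibitor), compound 1 gives 26100 nM.
compound 2 `CCc1cccc(C)c1-n1nncc1CN1C(=O)C2(C(C#N)=C(N)Oc3c(N)cc4nc5ccccc5nc4c32)c2ccccc21`: for compound 2 the reading in this assay is a limit, > 50000 nM.

Compound 2 therefore stands at the limit of > 50000 nM in this assay, at which 1 of the 2 values shown sits, with a floor and no number. Compound 3 `Cc1ccc(C)c(-n2nncc2CN2C(=O)C3(C(C#N)=C(N)Oc4c(N)cc5nc6ccccc6nc5c43)c3ccccc32)c1` differs from compound 2 by 2,5-dimethylphenyl in place of 2-ethyl-6-methylphenyl on an aromatic nitrogen. Within the data shown here, the only measured step at this aromatic nitrogen is an at least 1.9-fold higher number from compound 1 to compound 2 (0.28 log units; that floor lies within the scatter), an aryl exchange that ended at the limit. A further aryl exchange from compound 2 is expected to give a step that the limit leaves unreadable from compound 2 to compound 3 in this assay, nothing beyond the scatter. Compound 3 is estimated at 60000 nM, between 25000 nM and 150000 nM, probably again a limit.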

Compound 3, half-maximal inhibitory concentration: > 50000 nM
Compound 3 ended at the assay's limit; the forecaster's own chance of this, stated with the estimate: 60%; the middle value lies beyond the limit too.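

With 2,5-dimethylphenyl on the aromatic nitrogen, compound 3 joins compound 2 at the same limit in this assay, so this limit is no longer tied to a single aryl group: the limit of > 50000 nM in this assay, at which 2 of the 3 values shown sit.
Replacing 3-bromophenyl with 2,5-dimethylphenyl gives an at least 1.9-fold higher number from compound 1 to compound 3 (0.28 log units; that floor lies within the scatter) and so provides only a floor, as the earlier exchange did. The step between the two limit compounds cannot be read.
Still open, going by these compounds, is whether an amine or a carboxylic acid on this aryl ring, or a longer chain in its place, would give a reading short of the limit.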